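The compounds below may be only part of what the source reports. "The series", "measured", "known", "first", "only" and "open" are said of these compounds alone.

Measured so far in this series:
Compound 1, `CCCS(=O)(=O)Nc1ccc(F)c(C(=O)c2n[nH]c3ncc(-c4cccc(C)c4)cc23)c1F` — 15%
Compound 2, `CCCS(=O)(=O)Nc1ccc(F)c(C(=O)c2n[nH]c3ncc(-c4ccc(O)cc4)cc23)c1F` — 0.75%
Compound 3, `CCCS(=O)(=O)Nc1ccc(F)c(C(=O)c2n[nH]c3ncc(-c4ccc(C(C)C)cc4)cc23)c1F` — 17%

In an assay for binding affinity to dual specificity mitogen-activated protein kinase kinase 4 (Homo sapiens), read by KINOMEscan, tested at 100 nM (a lower number here means a stronger effect, a higher number a weaker effect of the compound at the concentration tested), compound 3 holds the highest of the three numbers. Its nearest neighbour is compound 1, and a number 2 percentage points higher from compound 1 to compound 3 (within the scatter), so the two are not separable. Its furthest is compound 2, and a number 16.3 percentage points higher from compound 2 to compound 3 (beyond the scatter).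

Compound 4, `CCCS(=O)(=O)Nc1ccc(F)c(C(=O)c2n[nH]c3ncc(-c4ccc(S(N)(=O)=O)cc4)cc23)c1F`, is the next member. The change from compound 3 is sulfamoyl in place of isopropyl on an aromatic carbon.

Among the measured compounds shown here, two measured steps bear on it. For the measured compounds named here, the first is the change at the same carbon in the reverse sense, where a number 16.3 percentage points higher from compound 2 to compound 3 (beyond the scatter); the second is a number 14.3 percentage points lower from compound 1 to compound 2 (beyond the scatter). Both show that a group carrying a hydrogen-bond donor at this position goes with a lower number, and the entering sulfamoyl brings one donor and two acceptors. A step downward beyond the scatter is therefore expected for compound 4, a number 12 percentage points lower from compound 3 to compound 4 (beyond the scatter), though whether it reaches the level of compound 2 is uncertain.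

Compound 4 is estimated at 5%, in a range from 0.5% to 20%.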

Compound 4, a percentage reported as activity, at one concentration (the size of the read-out at that concentration, not a potency): 0.25%
Compound 4: middle estimate off by 4.8 percentage points, on the high side; the measured number lies below the stated range.
By their numbers in this assay, from the lowest: compounds 4 and 2 (each within the scatter of the next); then compounds 1 and 3 (each within the scatter of the next).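

In this assay, the exchange of 4-isopropylphenyl for 4-sulfamoylphenyl gives a number 16.8 percentage points lower from compound 3 to compound 4 (beyond the scatter), and the exchange of 3-methylphenyl for the same group gives a number 14.8 percentage points lower from compound 1 to compound 4 (beyond the scatter), so the low end of the series is no longer held by 4-hydroxyphenyl alone. Sulfamoyl in place of hydroxy gives a number 0.5 percentage points lower from compound 2 to compound 4 (within the scatter), so this position accepts two different groups with no separable difference in the read-out. Nothing on hand accounts for this shared low level.

A methylsulfonyl group, or an amine or carboxylic acid, on the same aromatic carbon would help show whether the hydrogen-bond donor matters or whether acceptors alone suffice. A 3-hydroxyphenyl or 3-sulfamoylphenyl would separate the effect of the group from that of its place, since the steps from compound 1 change both.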